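From Nitrile to Ester on a Shared Core

A few compounds are considered here, and "the series" means these few. Any claim that something is new, unique, unknown or untested is made for them only; others in the source may bear on it.

Measured so far:
compound 1, `N#CCCn1nc(-c2ccccc2)ccc1=O` — 10.1%
compound 2, `Cc1ccc(=O)n(CC(=N)S)n1` — 31.5%

Of the compounds shown here, two have been tested in a functional assay on the whole organism (stomach) for inhibition, with Rattus norvegicus as the target, at a dose of 100 mg/kg by the intraduodenal route; on this read-out lower numbers stand for less inhibition and higher numbers for more inhibition at the one dose given (going by the name of the read-out). Compound 1 `N#CCCn1nc(-c2ccccc2)ccc1=O` gives 10.1% in this assay, the lower of the two numbers. Compound 2 `Cc1ccc(=O)n(CC(=N)S)n1` gives 31.5%, and the gap between these two values lies beyond the usual scatter of the measurement. Among the compounds with values here, the two compounds differ in more than one place, so their values show only that compound 1 sits at the bottom of what has been measured.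

Compound 3 `CCOC(=O)CCn1nc(-c2ccccc2)ccc1=O` has not been measured yet. It differs from compound 1 in a single place: ethoxycarbonyl in place of cyano on a saturated chain carbon, two bonds along the chain from an aromatic nitrogen. Within the data shown here, no measured pair shows what such an exchange does on this core, so there is nothing to lean on beyond the value of compound 1 itself. The step expected from this change, a number 4.9 percentage points higher from compound 1 to compound 3 (within the scatter), is small and not beyond the scatter. Compound 3 is therefore estimated to give 15% in this assay, in a range from 0% to 35%.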

Compound 3, a percentage reported as inhibition, in the whole organism at one dose (the size of the read-out at that dose, not a potency): 6.3%
For compound 3 the middle estimate is 8.7 percentage points above the measured one; the measured number falls inside the stated range.
By their numbers in this assay, from the lowest: compounds 3 and 1 (each within the scatter of the next); then compound 2.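

Within the data shown here, putting ethoxycarbonyl in place of cyano on a saturated chain carbon, two bonds along the chain from an aromatic nitrogen, gives the first direct comparison at this place on the shared core, and in this assay the exchange gives a number 3.8 percentage points lower from compound 1 to compound 3 (within the scatter). The entering group has 5 heavy atoms against 2 for the leaving one, and 2 hydrogen-bond acceptors against 1, yet this read-out does not separate the two groups at the single dose given, so these differences in size and acceptor count come with no change that can be told from the scatter. Nothing available explains why the two groups read alike.

The compounds shown leave open whether a carboxylic acid, an amine or a longer chain at this same place would give a number clearly different from those of compound 1 and compound 3. They also leave open whether the same exchange would read alike on a core carrying a different group in place of the phenyl ring of compound 1, such as a methyl group.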